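Carboxylic Acid in Place of Carboxamide on a Shared Core

This account rests on a few compounds, and the source may have more. Where it says the series, first, only, none or still open, it means among the compounds named here.

Measured compounds:
compound 1 `CC1CCC(=NNc2ccccc2)c2ncc(C(=O)O)c(=O)n21`: 1.2 umol/kg
compound 2 `Cc1nc2n(c(=O)c1C(N)=O)C(C)CCC2=NNc1ccccc1`: > 100 umol/kg (a limit)
compound 3 `CCc1nc2n(c(=O)c1C(N)=O)C(C)CCC2=NNc1ccccc1`: > 100 umol/kg (a limit)

In a functional assay on the whole organism with Rattus norvegicus as the target (on this read-out lower numbers stand for an effect already at smaller amounts and higher numbers for an effect only at larger amounts of compound), compound 1 gives 1.2 umol/kg. Compound 2 gives only > 100 umol/kg in this assay, which is a limit of the measurement and not a number. Compound 3 likewise gives only the limit > 100 umol/kg. The step that the two limits leave unreadable from compound 2 to compound 3 therefore cannot be read, since both ends sit at the limit of > 100 umol/kg in this assay, at which 2 of the 3 values shown sit.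

Compound 4 `Cc1nc2n(c(=O)c1C(=O)O)C(C)CCC2=NNc1ccccc1` differs from compound 2 by hydroxy in place of amino on a carbonyl carbon. Among the measured compounds shown here, no measured step covers this change. For the measured compounds named here, the only guide is compound 1, which carries the carboxy group and gives 1.2 umol/kg. Compound 4 is expected to give 3 umol/kg, within 0.8 umol/kg to 30 umol/kg, an estimated step of an at least 33-fold lower number from compound 2 to compound 4 (1.52 log units; beyond the scatter) from the limit.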

Compound 4, dose for 50% inhibition: > 320 umol/kg
Compound 4: only a limit was reported (the forecaster's own chance of this, stated with the estimate: 15%); at least 100-fold (2.02 log units) between middle value and limit.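

In this assay compound 4 gives > 320 umol/kg, which is a limit and not a number. Carrying the carboxy group is therefore not enough on its own: methyl in place of hydrogen on an aromatic carbon gives an at least 260-fold higher number from compound 1 to compound 4 (2.42 log units; beyond the scatter). The change from carbamoyl to carboxy itself cannot be read, since compound 2 and compound 4 both stand at limits. Left open is whether a smaller change on that aromatic carbon, such as a chlorine or an amine, would keep the effect of compound 1. Also open, from the compounds shown here alone, is how carbamoyl in place of carboxy would read on the core of compound 1.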